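Sulfonamide variation on the shared core: toward compound 3

This account rests on a few compounds, and the source may have more. Where it says the series, first, only, none or still open, it means among the compounds named here.

Measured so far:
Compound 1, `Cn1cc(/C=C2\C(=O)Nc3ccc(S(N)(=O)=O)cc32)c2ccccc21`: 81% in an assay on isolated protein for inhibition of serine/threonine-protein kinase Sgk1 (Homo sapiens), tested at 0.1 uM; a higher number here means a weaker effect of the compound at the concentration tested, a lower number a stronger effect
Compound 2, `COc1ccc2c(c1)c(/C=C1\C(=O)Nc3ccc(S(=O)(=O)N(C)C)cc31)cn2C`: 90% in this assay

Compound 2 stands with the higher of the two numbers in this assay, yet compound 1 lies within the scatter of it, so no order between the two can be read; both leave the kinase largely unaffected at the concentration tested. Compound 1 and compound 2 differ in more than one place, so their values are only taken side by side.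

Compound 3, `COc1ccc2c(c1)c(/C=C1\C(=O)Nc3ccc(S(N)(=O)=O)cc31)cn2C`, is the next point. It is derived from compound 2 by a single change, (amino in place of dimethylamino on a sulfonyl sulfur). Within the data shown here, with no measured single step of this kind on this core, the expectation is no step beyond the scatter in this assay, in either direction.

Compound 3 is therefore estimated at 85%, in a range from 68% to 100%, which means an expected step of a number 5 percentage points lower from compound 2 to compound 3 (within the scatter).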

Compound 3, a percentage reported as activity, at one concentration (the size of the read-out at that concentration, not a potency): 80%
For compound 3 the middle estimate is 5 percentage points above the measured one; low and high end bracket the measured number.
By their numbers in this assay, from the lowest: compounds 3, 1 and 2 (each within the scatter of the next).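

In this assay, two single changes on the shared core can now be read: amino in place of dimethylamino on a sulfonyl sulfur gives a number 10 percentage points lower from compound 2 to compound 3 (within the scatter) and methoxy in place of hydrogen on an aromatic carbon gives a number 1 percentage points lower from compound 1 to compound 3 (within the scatter) as its step. Both steps lie within the scatter, so neither change separates its pair of compounds at the concentration tested, and the dimethylsulfamoyl and sulfamoyl groups cannot be told apart on this core. Nothing at hand bears on what lies behind these steps.

Open, as far as these compounds go, is whether a larger group on the sulfonyl sulfur, such as morpholine or a longer alkylamine, would give a step beyond the scatter. Equally open, from the compounds shown here alone, is whether a group other than methoxy on that aromatic carbon, such as chlorine or a carboxylic acid, would do so.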